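Adding a second methoxy to the weakest of three analogues

The source may hold more compounds than are shown below. What is called first, only, known or untested is meant among the compounds shown, and "the series" means these compounds.

Of the compounds shown here, three sharing one core have been measured in an assay on isolated protein for inhibition of Rho-associated protein kinase 2 (Homo sapiens), read by radiometric assay and 33P incorporation, with a stated time of 40 min, in the presence of a further agent that is not named here; a lower number here means a stronger inhibitor, a higher number a weaker inhibitor. Compound 1 `COc1cccc(Cn2cnc3sc(-c4ccnc(N)c4)cc3c2=O)c1` gives 1 nM. Compound 2 `Nc1cc(-c2cc3c(=O)n(Cc4cccc(F)c4)cnc3s2)ccn1` gives 5 nM. Compound 3 `COc1ccc(Cn2cnc3sc(-c4ccnc(N)c4)cc3c2=O)cc1` gives 46 nM, the highest number of the three: the step of a 46-fold higher number from compound 1 to compound 3 (1.66 log units; beyond the scatter) is large, and the step of a 9.2-fold higher number from compound 2 to compound 3 (0.96 log units; beyond the scatter) is modest, so compound 3 is the weakest inhibitor here. The step of a 5.0-fold higher number from compound 1 to compound 2 (0.70 log units; beyond the scatter) is modest.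

Compound 4 `COc1ccc(Cn2cnc3sc(-c4ccnc(N)c4)cc3c2=O)cc1OC` differs from compound 3 by methoxy in place of hydrogen on an aromatic carbon. Within the data shown here, no measured step involves adding a second methoxy, so no step bears on the change directly. What the measured steps show is that moving a methoxy from the position it holds in compound 1 to the position it holds in compound 3 costs a large step, a 46-fold higher number from compound 1 to compound 3 (1.66 log units; beyond the scatter). Compound 4 keeps the methoxy of compound 3 and adds one that sits, as in compound 1, meta to the large group. The number for compound 4 in this assay is therefore expected to fall below that of compound 3, with the step of a 3.8-fold lower number from compound 3 to compound 4 (0.58 log units; beyond the scatter) estimated as modest, since the methoxy of compound 3 remains and compound 1 shows 1 nM without it. The estimate for compound 4 is 12 nM, in the range 3 nM to 50 nM.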

Compound 4, half-maximal inhibitory concentration: 219 nM
The estimate for compound 4 lay 18-fold (1.26 log units) below the measured number, and the stated range ends below it.
By their numbers in this assay, from the lowest: compound 1; then compound 2; then compound 3; then compound 4.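

In this assay, the second methoxy does not bring back the strength of compound 1; instead it moves the number the wrong way, with a 4.8-fold higher number from compound 3 to compound 4 (0.68 log units; beyond the scatter). A methoxy meta to the large group therefore does not help on its own terms: compound 1 carries one there and is the strongest of the set, yet the same group gives a weaker inhibitor when it is ortho to a methoxy group. Among these compounds, the gap to the best compound also widens, with a 220-fold higher number from compound 1 to compound 4 (2.34 log units; beyond the scatter), which is a larger step than the one from compound 1 to compound 3, so on this ring the effect of one methoxy depends on what else the ring carries, and the data give no measured explanation for this.

Still open, going by these compounds, is whether the rise in number belongs to methoxy in particular or would follow from any group at this place, such as a methyl, a chlorine or a hydroxyl. Equally open, on these data alone, is whether a pair of smaller groups, such as two fluorines, would be tolerated on this ring where two methoxy groups lose strength.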